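The source may report more compounds than this note shows. Statements on the series, on what has been measured and on what is new or still open speak of the compounds shown alone.

Compounds measured in an assay on CHO cells for antagonist activity at transient receptor potential cation channel subfamily V member 1 (Homo sapiens), read by FLIPR; on this read-out higher numbers stand for weaker inhibition and lower numbers for stronger inhibition:
compound 1 `CC(C(=O)NCc1ccc(C(F)(F)F)nc1-c1ccccc1F)c1ccc(NS(C)(=O)=O)c(F)c1`, 63.3 nM
compound 2 `CC(C(=O)NCc1ccc(C(F)(F)F)nc1-c1ccc(Cl)cc1)c1ccc(NS(C)(=O)=O)c(F)c1`, 0.7 nM
compound 3 `CC(C(=O)NCc1ccc(C(F)(F)F)nc1-c1cccc(Cl)c1)c1ccc(NS(C)(=O)=O)c(F)c1`, 0.5 nM

Compound 1 stands with the highest number of the three in this assay; its nearest neighbour is compound 2, with a 90-fold lower number from compound 1 to compound 2 (1.96 log units; beyond the scatter), and the furthest is compound 3, with a 130-fold lower number from compound 1 to compound 3 (2.10 log units; beyond the scatter). Between compound 2 and compound 3 the step is a 1.4-fold lower number from compound 2 to compound 3 (0.15 log units; within the scatter).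

Compound 4 `CC(C(=O)NCc1ccc(C(F)(F)F)nc1-c1ccco1)c1ccc(NS(C)(=O)=O)c(F)c1` has not yet been measured in this assay. It differs from compound 1 in one place: furan-2-yl in place of 2-fluorophenyl on an aromatic carbon.

Both measured steps from compound 1 bear on this change in the sense that each removes the 2-fluorophenyl, and each gave a large drop in the number; yet each also brings in a chlorophenyl, whereas compound 4 brings in a furan-2-yl, so neither step is a direct match. Weighing this, compound 4 is expected to show a lower number than compound 1, with the step estimated at a 6.3-fold lower number from compound 1 to compound 4 (0.80 log units; beyond the scatter), clearly beyond the scatter but smaller than the two chlorophenyl steps. Compound 4 is therefore estimated at 10 nM in this assay, within a range from 2 nM to 60 nM.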

Compound 4, inhibition constant: 5.8 nM
The estimate for compound 4 lay 1.7-fold (0.24 log units) above the measured number; low and high end bracket the measured number.
By their numbers in this assay, from the lowest: compounds 3 and 2 (each within the scatter of the next); then compound 4; then compound 1.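

In this assay, furan-2-yl at this position, next to the ring nitrogen, also lowers the number relative to 2-fluorophenyl (an 11-fold lower number from compound 1 to compound 4 (1.04 log units; beyond the scatter)), so a drop at this position does not require a chlorophenyl or even a six-membered ring. The furan-2-yl nevertheless stays short of both chlorophenyl groups (a 12-fold higher number from compound 3 to compound 4 (1.06 log units; beyond the scatter); an 8.3-fold higher number from compound 2 to compound 4 (0.92 log units; beyond the scatter)), which places it in an intermediate position among the four groups shown. Nothing available explains these differences.

The compounds shown leave open where an unsubstituted phenyl, a 2-chlorophenyl or a thiophen-2-yl would fall, so the contributions of ring size and of the substituent and its place on the phenyl remain unseparated. Also open, from the compounds shown here alone, is how a saturated ring amine such as piperidine or morpholine would read at this position.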